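The compounds below may be only part of what the source reports. "The series", "measured", "known", "first", "only" and "open" are said of these compounds alone.

Working notes on the series.

Compound 1 `N#Cc1c(-c2ccc(Cl)cc2)nc(SCC(=O)Nn2c(COc3ccc(Cl)cc3Cl)nc3ccccc3c2=O)n(Cc2ccccc2)c1=O` and compound 2 `N#Cc1c(-c2ccc(O)cc2)nc(SCC(=O)Nn2c(COc3ccc(Cl)cc3Cl)nc3ccccc3c2=O)n(Cc2ccccc2)c1=O` share one core, compound 3 `N#Cc1c(Nc2ccc(Cl)cc2)nc(SCC(=O)Nn2c(COc3ccc(Cl)cc3Cl)nc3ccccc3c2=O)nc1-c1ccc(O)cc1` and compound 4 `N#Cc1c(Nc2ccc(O)cc2)nc(SCC(=O)Nn2c(COc3ccc(Cl)cc3Cl)nc3ccccc3c2=O)nc1-c1ccc(O)cc1` another; the difference between the two cores is not broken down here. In a functional assay on the whole organism (strain albino) for inhibition, with Rattus norvegicus as the target, read by paw edema, with stated times of 1 h and 2 h, at a dose of 100 mg/kg by the oral route (on this read-out higher numbers stand for more inhibition at the one dose given (going by the name of the read-out) and lower numbers for less inhibition), compound 1 gives 77.2% and compound 2 gives 56.1%. The change between them, (hydroxy in place of chloro on an aromatic carbon), gave a step of a number 21.1 percentage points lower from compound 1 to compound 2 (beyond the scatter). In this assay, going by the values given here, compound 3 gives 77.2%, level with compound 1 at the digits printed and within the scatter of it, and together with compound 1 the highest of the three numbers so far.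

Compound 4 carries the same change on the other core, (hydroxy in place of chloro on an aromatic carbon), at a place on an aromatic carbon of a six-membered aromatic ring of carbon only, para to a large group, as in the first pair. Among the compounds with values here, the expectation for compound 4 rests on the single earlier instance, because a number 21.1 percentage points lower from compound 1 to compound 2 (beyond the scatter) is the only measured step of this kind, and with two hydroxyphenyl groups in compound 4 the step is expected to be of comparable size, a number 19.2 percentage points lower from compound 3 to compound 4 (beyond the scatter). In this assay compound 4 is therefore estimated at 58%, with an expected range from 42% to 74%.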

Compound 4, a percentage reported as inhibition, in the whole organism at one dose (the size of the read-out at that dose, not a potency): 86.8%
The estimate for compound 4 lay 28.8 percentage points below the measured number, and the stated range ends below it.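

Going by these compounds alone, on the core of compound 3, hydroxy in place of chloro gave a number 9.6 percentage points higher from compound 3 to compound 4 (within the scatter) in this assay, so on this core the change leaves no step that can be told from the scatter. The step seen on the core of compound 1 therefore did not carry over to the other core, and the two steps differ: the same change on two cores in this assay, a number 21.1 percentage points lower (beyond the scatter) from compound 1 to compound 2 and a number 9.6 percentage points higher (within the scatter) from compound 3 to compound 4, 30.7 percentage points apart, beyond the scatter of two such steps. This does not show why they differ or give a rule for other cores: each core offers a single pair at one dose, the change lies on 4-chlorophenyl to 4-hydroxyphenyl in one pair and on (4-chlorophenyl)amino to (4-hydroxyphenyl)amino in the other, and the core and the attachment of the ring cannot be separated.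

Open, from the compounds shown here alone, is whether an amine or a carboxylic acid in place of the hydroxy would follow either pair. Also open, going by these compounds, is how the step reads on the core of compound 3 with a 4-chlorophenyl group in place of its remaining 4-hydroxyphenyl group.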